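A few compounds are considered here, and "the series" means these few. Any claim that something is new, unique, unknown or untested is made for them only; others in the source may bear on it.

Measured compounds:
Compound 1, `CC[C@H](C)C(=O)O[C@H]1C[C@H](O)C=C2C=C[C@H](C)[C@H](CCC(O)C[C@H](O)CC(=O)O)[C@]21C`: in an assay on microsomes from liver for inhibition of 3-hydroxy-3-methylglutaryl-coenzyme A reductase (Rattus norvegicus) (a higher number here means a weaker inhibitor, a lower number a stronger inhibitor), compound 1 gives 5 nM.
Compound 2, `Cc1cccc(-c2nc(C(F)(F)F)n(CC[C@@H](O)C[C@@H](O)CC(=O)O)c2-c2ccc(F)cc2)c1`: in this assay compound 2 gives 29 nM.

For the measured compounds named here, of the two numbers, compound 2 stands at the higher one; compound 1 is its only neighbour, and the gap between the two values lies beyond the usual scatter, so compound 1 is the stronger inhibitor of the pair.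

The step to compound 3, `COc1ccc(-c2nc(C(F)(F)F)n(CC[C@@H](O)C[C@@H](O)CC(=O)O)c2-c2ccc(F)cc2)cc1`, changes the aryl group on the five-membered ring: 4-methoxyphenyl in place of 3-methylphenyl on an aromatic carbon. Going by the values given here, nothing among the measured compounds shows what such an exchange of one aryl substituent for another does in this assay, so no direction can be taken from data. The account expects a step of a 1.0-fold higher number from compound 2 to compound 3 (0.01 log units; within the scatter), which is to say none beyond the scatter. Compound 3 is therefore estimated at 30 nM, within a range of 10 nM to 90 nM.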

Compound 3, half-maximal inhibitory concentration: 68 nM
The estimate for compound 3 lay 2.3-fold (0.36 log units) below the measured number; measured number inside the range.
By their numbers in this assay, from the lowest: compound 1; then compound 2; then compound 3.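

In this assay the group on the aromatic carbon next to the ring nitrogen proves not to be interchangeable: 4-methoxyphenyl in place of 3-methylphenyl gives a 2.3-fold higher number from compound 2 to compound 3 (0.37 log units; beyond the scatter) and so moves the number in the direction of a weaker inhibitor. For the compounds shown here, the step is modest, but it is the first reading of this position, and it shows that the aryl group there matters. Nothing measured on these compounds accounts for the step.

The exchange alters both the substituent and its place on the phenyl ring, and the compounds shown do not separate the two, which 3-methoxyphenyl or 4-methylphenyl would do. Also open, on these data alone, is how this position responds to an unsubstituted phenyl or to a group carrying an amine, such as 4-aminophenyl.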